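Amine and Hydroxyl Variation in a Lipid Carbamate Series

This account rests on a few compounds, and the source may have more. Where it says the series, first, only, none or still open, it means among the compounds named here.

Measured compounds:
compound 1 `CCCCCCCCCCCCCC[C@H](OCOC)[C@H](CN(C(C)C)C(C)C)NC(=O)OC(C)(C)C`: 53.9%
compound 2 `CCCCCCCCCCCCCC[C@H](OCOC)[C@H](CN(CCCC)CCCC)NC(=O)OC(C)(C)C`: 56.1%
compound 3 `CCCCCCCCCCCCCC[C@H](O)[C@H](CN(C(C)C)C(C)C)NC(=O)OC(C)(C)C`: 34.8%

In a functional assay on DLD-1 cells (Homo sapiens) for antiproliferative activity, read by sulforhodamine B assay, with a stated time of 48 h, tested at 10 uM (on this read-out higher numbers stand for more inhibition at the one concentration tested (going by the name of the read-out) and lower numbers for less inhibition), compound 1 gives 53.9% and compound 2 gives 56.1%. The change between them is dibutylamino in place of diisopropylamino on a saturated chain carbon, two bonds along the chain from an amide-type nitrogen; the step is a number 2.2 percentage points higher from compound 1 to compound 2 (within the scatter). Compound 3 gives 34.8% after (hydrogen in place of methoxymethyl on an oxygen on a saturated carbon), a step of a number 19.1 percentage points lower from compound 1 to compound 3 (beyond the scatter). Compound 3 is the lowest of the three.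

Compound 4 `CCCCCCCCCCCCCC[C@H](O)[C@H](CN(CCCC)CCCC)NC(=O)OC(C)(C)C` is not yet measured. It differs from compound 3 by dibutylamino in place of diisopropylamino on a saturated chain carbon, two bonds along the chain from an amide-type nitrogen, the same change as from compound 1 to compound 2, at the same place. The cores of compounds 3 and 4 differ from those of compounds 1 and 2 by hydrogen in place of methoxymethyl on an oxygen on a saturated carbon.

The step from compound 3 to compound 4 is expected to be a number 2.2 percentage points higher from compound 3 to compound 4 (within the scatter), within the scatter, because in this assay the same change gave a number 2.2 percentage points higher from compound 1 to compound 2 (within the scatter). Compound 4 is therefore estimated at 37%, between 25% and 50%.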

Compound 4, a percentage reported as inhibition, at one concentration (the size of the read-out at that concentration, not a potency): 23.4%
Estimate against measurement, compound 4: 13.6 percentage points above; the measured number lies below the stated range.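

In this assay, dibutylamino in place of diisopropylamino on the hydroxyl core gives a number 11.4 percentage points lower from compound 3 to compound 4 (beyond the scatter), and hydrogen in place of methoxymethyl gives a number 32.7 percentage points lower from compound 2 to compound 4 (beyond the scatter). The amine change is not shown to act differently on the two cores, though one pair per core cannot establish that it carries over reliably: the same change on two cores in this assay, a number 2.2 percentage points higher (within the scatter) from compound 1 to compound 2 and a number 11.4 percentage points lower (beyond the scatter) from compound 3 to compound 4, 13.6 percentage points apart, within the scatter of two such steps The same limit applies to removing methoxymethyl, which lowers the number in both pairs, while the size of that drop is not shown to depend on the amine: the same change on two cores in this assay, a number 19.1 percentage points lower (beyond the scatter) from compound 1 to compound 3 and a number 32.7 percentage points lower (beyond the scatter) from compound 2 to compound 4, 13.6 percentage points apart, within the scatter of two such steps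

The compounds shown leave open how cyclic amines such as piperidine or morpholine would fit these steps. As far as these compounds go, a free primary amine in place of the tert-butyl carbamate, or a shorter alkyl chain, also remains open.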